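The source may hold more compounds than are shown below. What is called first, only, known or untested is meant among the compounds shown, and "the series" means these compounds.

The series shares one core, seen in compound 1 `Brc1ccc(-c2ncc(OCC3CCNCC3)nc2-c2ccc(Br)cc2)cc1`, compound 2 `Brc1ccc(-c2ncc(OCC3CCNCC3)nc2-c2ccc(Br)c(Br)c2)cc1Br` and compound 3 `N#Cc1ccc(-c2ncc(OCC3CCNCC3)nc2-c2ccc(C#N)cc2)cc1`. In an assay on isolated protein for inhibition of histone acetyltransferase p300 (Homo sapiens), read by scintillation counting, with stated times of 10 min and 30 min (a higher number here means a weaker inhibitor, a lower number a stronger inhibitor), compound 1 gives 5700 nM. In this assay compound 2 gives 10000 nM. For compound 3 this assay reports only a limit, > 10000 nM, and that is where compound 3 stands: a limit, not a number, as recorded in the limit of > 10000 nM in this assay, at which 1 of the 3 values shown sits. Among the measured compounds shown here, no two measured compounds differ in a single place, so no step can be read off directly. Compound 4 `N#Cc1ccc(-c2nc(OCC3CCNCC3)cnc2-c2ccc(Br)cc2)cc1` is not yet measured. It differs from compound 3 by bromo in place of cyano on an aromatic carbon. The same exchange made twice over separates compound 3 from compound 1, and the two values of those compounds show a limit against a measured number. The expected step, an at least 1.2-fold lower number from compound 3 to compound 4 (0.09 log units; that floor lies within the scatter), is a move from the limit toward a measurable number, with a fair chance that the assay again reports only a limit. Compound 4 is estimated at 8000 nM, with a range from 3000 nM to 20000 nM.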

Compound 4, half-maximal inhibitory concentration: > 10000 nM
Compound 4 gave a limit, no number; the forecaster's own chance of this, stated with the estimate: 40%; middle value at least 1.2-fold (0.09 log units) away from the limit.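

In this assay compound 4 gives > 10000 nM as a limit of the assay, not a number. With one bromo in place of one cyano, the value still stays at the limit, and the step between compound 3 and compound 4 cannot be read, since both compounds sit at that limit: the limit of > 10000 nM in this assay, at which 2 of the 4 values shown sit.

The one readable step at this position is an at least 1.7-fold higher number from compound 1 to compound 4 (0.24 log units; that floor lies within the scatter) for cyano in place of bromo on an aromatic carbon, so this exchange is not shown to act beyond the usual scatter.

On these data alone, how far compound 3 and compound 4 lie past the limit remains open. Also open, as far as these compounds go, is whether another group at this position, such as an amine or a carboxylic acid, would give a measurable number.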